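Working notes: from compound 2 to compound 3

The source may hold more compounds than are shown below. What is called first, only, known or untested is meant among the compounds shown, and "the series" means these compounds.

- compound 1 `Cc1cccc(NS(=O)(=O)c2ccc(N3CCNC3=O)cc2)c1`: 110 nM
- compound 2 `Cc1cccc(NS(=O)(=O)c2ccc(N3CCNC3=O)cc2)c1C`: 190 nM

In a functional assay on HT-29 cells (Homo sapiens) for antiproliferative activity, read by sulforhodamine B assay, with a stated time of 48 h (a higher number here means a weaker inhibitor, a lower number a stronger inhibitor), compound 2 gives 190 nM, the higher of the two numbers but within the scatter of compound 1 at 110 nM. Compound 3 `COc1ccccc1NS(=O)(=O)c1ccc(N2CCNC2=O)cc1` carries 2-methoxyphenyl in place of 2,3-dimethylphenyl on a sulfonamide nitrogen. Among the compounds with values here, the only measured step bearing on this is a 1.7-fold higher number from compound 1 to compound 2 (0.24 log units; within the scatter), a methyl in place of hydrogen on an aromatic carbon. Within the data shown here, no measured compound carries 2-methoxyphenyl, so that step is only a weak guide. In this assay no step beyond the scatter is expected, and the expected step is a 1.1-fold higher number from compound 2 to compound 3 (0.02 log units; within the scatter). The estimate for compound 3 is 200 nM, with an expected range of 60 nM to 800 nM.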

Compound 3, half-maximal inhibitory concentration: 550 nM
Estimate against measurement, compound 3: 2.8-fold (0.44 log units) below, within the range that was stated.
By their numbers in this assay, from the lowest: compounds 1 and 2 (each within the scatter of the next); then compound 3.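

In this assay, the group on the sulfonamide nitrogen now shows a change beyond the scatter: 2-methoxyphenyl in place of 2,3-dimethylphenyl gives (a 2.9-fold higher number from compound 2 to compound 3 (0.46 log units; beyond the scatter)), and 2-methoxyphenyl in place of 3-methylphenyl gives (a 5.0-fold higher number from compound 1 to compound 3 (0.70 log units; beyond the scatter)). The earlier methyl step stayed within the scatter, so among these three compounds only the exchange for 2-methoxyphenyl separates the numbers. The data offer no measurement that explains this rise.

As far as these compounds go, whether the rise follows the methoxy oxygen or the missing methyl groups stays open. From the compounds shown here alone, how an amine or a carboxylic acid on this phenyl ring would read is also open.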